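Aryl change on the double-bonded carbon: compound 3

A few compounds are considered here, and "the series" means these few. Any claim that something is new, unique, unknown or untested is made for them only; others in the source may bear on it.

Measured so far:
compound 1 `COc1ccc(/C=N/NC(=O)Nc2cc3c(Nc4ccc(F)c(Cl)c4)ncnc3cc2O[C@H]2CCOC2)cc1` — 27300 nM
compound 2 `O=C(N/N=C/c1ccc(O)c(Br)c1)Nc1cc2c(Nc3ccc(F)c(Cl)c3)ncnc2cc1O[C@H]1CCOC1` — 2690 nM

In a functional assay on MCF7 cells (Homo sapiens) for cytotoxicity, read by MTT assay, with a stated time of 72 h (on this read-out lower numbers stand for stronger inhibition and higher numbers for weaker inhibition), compound 2 gives 2690 nM, the lowest of the two numbers; its nearest neighbour is compound 1, which gives 27300 nM. Among the compounds with values here, the single measured step, a 10-fold lower number from compound 1 to compound 2 (1.01 log units; beyond the scatter), is the only information on how the aryl group on the carbon with a double bond to nitrogen affects this assay.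

Compound 3 `CCN(CC)c1ccc(/C=N/NC(=O)Nc2cc3c(Nc4ccc(F)c(Cl)c4)ncnc3cc2O[C@H]2CCOC2)c(O)c1` differs from compound 2 by 4-(diethylamino)-2-hydroxyphenyl in place of 3-bromo-4-hydroxyphenyl on a carbon with a double bond to nitrogen. Within the data shown here, no measured step covers this exchange directly; the step from compound 1 to compound 2 shows only that this group can shift the number a great deal, in either direction for all that is known. Compound 3 is therefore expected to stay broadly near compound 2, with a 1.9-fold higher number from compound 2 to compound 3 (0.27 log units; within the scatter) expected as a small step toward a higher number and a wide range on both sides. The estimate for compound 3 is 5000 nM, between 1000 nM and 25000 nM.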

Compound 3, half-maximal inhibitory concentration: 15600 nM
Estimate against measurement, compound 3: 3.1-fold (0.49 log units) below, within the range that was stated.
By their numbers in this assay, from the lowest: compound 2; then compounds 3 and 1 (each within the scatter of the next).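

In this assay, the exchange of 3-bromo-4-hydroxyphenyl for 4-(diethylamino)-2-hydroxyphenyl gives a 5.8-fold higher number from compound 2 to compound 3 (0.76 log units; beyond the scatter), so a hydroxyphenyl group on the carbon with a double bond to nitrogen does not by itself keep the number of compound 2. The second exchange, a 1.8-fold lower number from compound 1 to compound 3 (0.24 log units; within the scatter), leaves 4-methoxyphenyl and 4-(diethylamino)-2-hydroxyphenyl indistinguishable here, although only the latter carries a hydroxyl, and so far only 3-bromo-4-hydroxyphenyl stands apart from the other two aryl groups. No measurement at hand gives a reason for this difference.

The compounds shown leave open whether the lower number of compound 2 depends on the bromine, the hydroxyl or the two together, since no aryl group carries one without the other in that arrangement. A 3-bromophenyl and a plain 4-hydroxyphenyl at this position would separate the two contributions.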